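The source may report more compounds than this note shows. Statements on the series, on what has been measured and on what is new or still open speak of the compounds shown alone.

Measured in a functional assay on A2780 cells (Homo sapiens) for antiproliferative activity, read by MTT assay, with a stated time of 48 h (a lower number here means a stronger inhibitor, a higher number a weaker inhibitor), so far:
compound 1 `COc1ccc(-c2cc3c(cn2)[nH]c(=O)n3-c2cc(OC)c(OC)c(OC)c2)cc1O` gives 240 nM
compound 2 `COc1ccc(-c2cc3c(cn2)n(C)c(=O)n3-c2cc(OC)c(OC)c(OC)c2)cc1O` gives 1720 nM
compound 3 `COc1ccc(-c2cc3c(cn2)n(C(C)C)c(=O)n3-c2cc(OC)c(OC)c(OC)c2)cc1O` gives 3160 nM

Compound 3 shares the high end of these numbers with one other compound. The step of a 1.8-fold higher number from compound 2 to compound 3 (0.26 log units; within the scatter) separates that pair, while the step of a 13-fold higher number from compound 1 to compound 3 (1.12 log units; beyond the scatter) shows its distance from the compound with hydrogen on that nitrogen. Compound 4 `COc1ccc(-c2cc3c(cn2)n(C2CC2)c(=O)n3-c2cc(OC)c(OC)c(OC)c2)cc1O` follows with cyclopropyl in place of isopropyl on an aromatic nitrogen and nothing else altered. Among the compounds with values here, three measured steps bear on this. Hydrogen gave way to methyl in the step of a 7.2-fold higher number from compound 1 to compound 2 (0.86 log units; beyond the scatter) and to isopropyl in the larger step already shown, so both replacements raised the number beyond the scatter. Methyl gave way to isopropyl with no change beyond it. Compound 4 also keeps a carbon group on that nitrogen, so in this assay it is expected to stay close to the two substituted compounds, with no clear shift in either direction. The expected value of compound 4 is 2500 nM within an estimated range from 1000 nM to 6000 nM for this read-out. That estimate means a 1.3-fold lower number from compound 3 to compound 4 (0.10 log units; within the scatter) as the expected step, with nothing beyond the scatter.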

Compound 4, half-maximal inhibitory concentration: > 20000 nM
Compound 4: no number, only a limit; the forecaster's own chance of this, stated with the estimate: 5%; middle value at least 8.0-fold (0.90 log units) from the limit.
By their numbers in this assay, from the lowest: compound 1; then compounds 2 and 3 (each within the scatter of the next). At a limit, above all of these: compound 4.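

In this assay compound 4 gives > 20000 nM, which is a limit of the assay and not a number. Isopropyl and cyclopropyl have the same count of heavy atoms, yet the change to the three-membered ring brings an at least 6.3-fold higher number from compound 3 to compound 4 (0.80 log units; beyond the scatter), so at this nitrogen the count of heavy atoms alone does not set the number, and the earlier near-equality of methyl and isopropyl does not extend to every carbon group. The new ring also stands well apart from the other two groups, with an at least 11-fold higher number from compound 2 to compound 4 (1.06 log units; beyond the scatter) against methyl and an at least 83-fold higher number from compound 1 to compound 4 (1.92 log units; beyond the scatter) against hydrogen.

How far beyond the limit compound 4 lies remains unknown, and the compounds shown give no cause for the loss. Also open, as far as these compounds go, is whether an ethyl group, a cyclobutyl ring or a longer chain on this nitrogen would stay with methyl and isopropyl or fall with cyclopropyl.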